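Trimming the Chain of Compound 2

The compounds below may be only part of what the source reports. "The series", "measured", "known", "first", "only" and "open" are said of these compounds alone.

- Compound 1 `CCCCCCCCCCCCNC[C@@H]1OC[C@H](N)[C@H]1O`: 12600 nM
- Compound 2 `CCCCCCCCCCCCCCNC[C@@H]1OC[C@H](N)[C@H]1O`: 8830 nM
- Compound 3 `CCCCCCCCCCCCNC[C@@H]1OC[C@H](N)[C@@H]1O`: 1800 nM

All three values come from a functional assay on MCF7 cells (Homo sapiens) for antiproliferative activity, read by MTT assay, with a stated time of 72 h; on this read-out higher numbers stand for weaker inhibition and lower numbers for stronger inhibition. In this set, compound 2 at 8830 nM lies within the scatter of compound 1 and well above compound 3 at 1800 nM. The next structure is compound 4 `CCCCCCCCCCCNC[C@@H]1OC[C@H](N)[C@H]1O`, which is reached from compound 2 by hydrogen in place of propyl on a saturated chain carbon, ten or more bonds along the chain from an amine nitrogen.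

Within the data shown here, only one measured step changes the chain. This is a 1.4-fold lower number from compound 1 to compound 2 (0.15 log units; within the scatter), which stays within the scatter and places ethyl where hydrogen stood, at a similar place on the chain. The change to compound 4 runs the opposite way and is somewhat larger. The much clearer a 7.0-fold lower number from compound 1 to compound 3 (0.85 log units; beyond the scatter) goes with the fact that compounds 1 and 3 differ only in the configuration as drawn, and compound 4 keeps the drawn configuration of compound 1 rather than that of compound 3, so this step offers no guide here.

In this assay, a small rise in the number is therefore expected, probably no larger than the scatter. The estimate amounts to a 1.5-fold higher number from compound 2 to compound 4 (0.18 log units; within the scatter), an expected step. For compound 4 the expected value is 13500 nM, with an estimated range from 6500 nM to 28000 nM.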

Compound 4, half-maximal inhibitory concentration: 13100 nM
Beside the measured number, compound 4's estimate is 1.0-fold (0.01 log units) above it, within the range that was stated.
By their numbers in this assay, from the lowest: compound 3; then compounds 2, 1 and 4 (each within the scatter of the next).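

In this assay, the shortening of the chain gives a 1.5-fold higher number from compound 2 to compound 4 (0.17 log units; within the scatter) and, measured against the other chain already in hand, a 1.0-fold higher number from compound 1 to compound 4 (0.02 log units; within the scatter), so neither step leaves the scatter. The earlier compounds had shown only one chain step, a 1.4-fold lower number from compound 1 to compound 2 (0.15 log units; within the scatter), running towards the longer chain; compound 4 adds the shorter direction, and with the drawn configuration of compound 1 kept, the chain changes now show no step beyond the scatter in either direction among compounds 1, 2 and 4. Nothing at hand says why these changes at the chain end leave the number within the scatter.

What the compounds shown leave open is whether the same flat picture would hold for a much shorter chain, or for a chain ending in an amine or a carboxylic acid. They also leave open whether shortening or lengthening the chain would stay within the scatter on the drawn configuration of compound 3, since that configuration appears here with one chain only.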